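The compounds below may be only part of what the source reports. "The series", "measured", "known", "first", "only" and "open" are said of these compounds alone.

Measured so far:
Compound 1 `CCn1cc(Nc2ncc3cccc(Nc4ccc(OC)cc4)c3n2)cn1` — a limit of > 1000 nM in an assay on isolated protein for inhibition of eIF-2-alpha kinase GCN2 (Homo sapiens); on this read-out lower numbers stand for stronger inhibition and higher numbers for weaker inhibition.
Compound 2 `COCCNC(=O)CCNc1ncc2c(Br)nn(-c3ccc4ncccc4c3)c2n1` — a limit of > 1000 nM in this assay.
Compound 3 `COCCS(=O)(=O)N[C@@H]1CC[C@@H](Nc2ncc3c(Br)nn(-c4ccc5ncccc5c4)c3n2)C1` — 55 nM in this assay.

Compound 2 stands at the limit of > 1000 nM in this assay, at which 2 of the 3 values shown sit, a limit rather than a number. Compound 3 alone gives a number, and it lies well inside the measured range. The step to compound 4 `CS(=O)(=O)N1CC[C@@H](Nc2ncc3c(Br)nn(-c4ccc5ncccc5c4)c3n2)C1` replaces (1-(methylsulfonyl)pyrrolidin-3-yl in place of 2-((2-methoxyethyl)carbamoyl)ethyl on a nitrogen on an aromatic ring). Among the compounds with values here, no measured step covers this exchange, so its size is open; the account expects a move toward stronger inhibition in this assay, beyond the scatter, since compound 3 with its sulfonyl group gives 55 nM. Compound 4 is expected at about 150 nM, in the range 30 nM to 1000 nM. This estimate means a step of an at least 6.6-fold lower number from compound 2 to compound 4 (0.82 log units; beyond the scatter).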

Compound 4, half-maximal inhibitory concentration: 90 nM
Compound 4: middle estimate off by 1.7-fold (0.22 log units), on the high side; the range from low to high includes it.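

Within the data shown here, putting 1-(methylsulfonyl)pyrrolidin-3-yl in place of 2-((2-methoxyethyl)carbamoyl)ethyl on a nitrogen on an aromatic ring gives in this assay an at least 11-fold lower number from compound 2 to compound 4 (1.04 log units; beyond the scatter) and is the first measured step at this position. It shows that the group held on this nitrogen alone can take the shared core from a limit to a measured number. Going by these compounds, the true size of the step remains unknown because compound 2 has only a limit: the limit of > 1000 nM in this assay, at which 2 of the 4 values shown sit.

On these data alone, the ring and the methylsulfonyl group enter together, so their shares stay open. A free pyrrolidine amine or an acetyl group on the ring nitrogen would separate them.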